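A few compounds are considered here, and "the series" means these few. Any claim that something is new, unique, unknown or untested is made for them only; others in the source may bear on it.

Compound 3 `COc1ccc2nc(C(=O)Nc3c(F)cc(-c4cccc(F)c4)cc3F)c(C)c(C(=O)O)c2c1` gives 0.68% in a functional assay on Hep 3B2 cells (Homo sapiens) for antiproliferative activity, read by MTT assay, with a stated time of 24 h, tested at 0.41 ug/mL (on this read-out lower numbers stand for a weaker effect and higher numbers for a stronger effect at the one concentration tested), the lowest of the three numbers shown, though compound 2 `Cc1c(C(=O)Nc2c(F)cc(-c3cccc(F)c3)cc2F)nc2ccc(F)cc2c1C(=O)O` with 1.06% lies within the scatter of it, and only compound 1 `Cc1ccc2nc(C(=O)Nc3c(F)cc(-c4cccc(F)c4)cc3F)c(C)c(C(=O)O)c2c1` with 15.2% stands clearly apart. Compound 4 `Cc1c(C(=O)Nc2c(F)cc(-c3cccc(F)c3)cc2F)nc2ccc(C(F)(F)F)cc2c1C(=O)O` differs from compound 3 by trifluoromethyl in place of methoxy on an aromatic carbon. Within the data shown here, two measured steps touch the same aromatic carbon: a number 14.5 percentage points lower from compound 1 to compound 3 (beyond the scatter) and a number 0.4 percentage points lower from compound 2 to compound 3 (within the scatter). The second, methoxy in place of fluoro, changed nothing beyond the scatter, so a low read-out held for both of those groups at this carbon, with only the methyl of compound 1 running against it. Compound 4 is therefore expected to show a number 1.3 percentage points higher from compound 3 to compound 4 (within the scatter), no step beyond the scatter. Compound 4 is estimated at 2%, between 0% and 12%.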

Compound 4, a percentage reported as inhibition, at one concentration (the size of the read-out at that concentration, not a potency): 6.42%
The estimate for compound 4 lay 4.4 percentage points below the measured number; low and high end bracket the measured number.
By their numbers in this assay, from the lowest: compounds 3, 2, 4 and 1 (each within the scatter of the next, the first and the last beyond it).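

Trifluoromethyl on this aromatic carbon gives a number 5.7 percentage points higher from compound 3 to compound 4 (within the scatter) and a number 5.4 percentage points higher from compound 2 to compound 4 (within the scatter) and so does not separate from methoxy or fluoro. Against methyl it gives a number 8.8 percentage points lower from compound 1 to compound 4 (within the scatter) and so, unlike methoxy and fluoro, does not separate from methyl either. Compound 4 thus lies within the scatter of all three other compounds, although compound 1 and compound 3 stand apart, which leaves it tied to neither end of the range.

Going by these compounds, whether an amine or a carboxylic acid at this carbon would move the number beyond the scatter stays open. Nothing available here explains the numbers at this position.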